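Swapping methoxy for bromo on the aryl of compound 2

The compounds below may be only part of what the source reports. "The series", "measured", "known", "first", "only" and "open" are said of these compounds alone.

This account follows a single change within a small series tested in a functional assay on FOCUS cells (Homo sapiens) for inhibition, read by sulforhodamine B assay, with a stated time of 72 h; a lower number here means a stronger inhibitor, a higher number a weaker inhibitor. Compound 1 `CC(C)Cc1ccc(C(C)c2n[nH]c(=S)n2N)cc1` carries an open-chain amino-thione core; in this assay compound 1 gives "not active" (no number reported), so no number is available for it. Compound 2 `COc1ccc(C2=Nn3c(nnc3C(C)c3ccc(-c4ccccc4)c(F)c3)SC2)cc1` has a fused bicyclic core with a 4-methoxyphenyl group attached; in this assay compound 2 gives 4400 nM. Among the compounds described here, compound 2 therefore holds the only numerical result, the other entry having been reported without a single number.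

Compound 3 `CC(c1ccc(-c2ccccc2)c(F)c1)c1nnc2n1N=C(c1ccc(Br)cc1)CS2` differs from compound 2 in one place only: bromo in place of methoxy on an aromatic carbon. The remaining parts of the structure are kept unchanged. Within the data shown here, no measured pair in this set isolates such a swap, so the size of the step can only be expected rather than read off. Because compound 2 gives 4400 nM and the change is a single substituent exchange at the far end of the molecule, the expected step is small, with no clear direction beyond the scatter. The expectation for compound 3 in this assay is an estimated 4000 nM, with a range from 1500 nM to 12000 nM. That corresponds to an expected step of a 1.1-fold lower number from compound 2 to compound 3 (0.04 log units; within the scatter).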

Compound 3, half-maximal inhibitory concentration: 8500 nM
Compound 3: middle estimate off by 2.1-fold (0.33 log units), on the low side, within the range that was stated.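

The exchange of 4-methoxyphenyl for 4-bromophenyl amounts to a 1.9-fold higher number from compound 2 to compound 3 (0.29 log units; within the scatter) in this assay and so does not separate the two compounds. Among these compounds, this pair gives the only direct reading of this position, on an aromatic carbon para to a large group, and it shows that a measurable number in this read-out does not depend on the methoxy group: compound 3, with a single bromine there and no hydrogen-bond acceptor in that substituent, also gives a number, and one within the usual scatter of the number for compound 2. No measurement shown here accounts for this result, and the pair offers no explanation of its own.

What the compounds shown leave open is how this position responds to groups of a different kind, such as an amine, a carboxylic acid, or a longer chain such as ethoxy, and to plain hydrogen. Among the compounds shown here, a single pair also cannot show whether bromo and methoxy would read alike on another core, and compound 1, which has no number, offers no step that can be read.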